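Working notes: aryl imidazoline series, agonist maximal response

The source may hold more compounds than are shown below. What is called first, only, known or untested is meant among the compounds shown, and "the series" means these compounds.

Measured compounds:
compound 1, `COc1ccc(SC)c(NCC2=NCCN2)c1`, 92%
compound 2, `CSc1ccc(Cl)cc1NCC1=NCCN1`, 103%

In a functional assay for agonist activity at Alpha-1B adrenergic receptor (Homo sapiens) (on this read-out lower numbers stand for smaller maximal responses and higher numbers for larger maximal responses), compound 2 gives 103%, the higher of the two numbers recorded so far. Compound 1 gives 92% in this assay. Within the data shown here, the only step measured between them, a number 11 percentage points higher from compound 1 to compound 2 (beyond the scatter), lies beyond the scatter but is modest in size.

Compound 3, `CSc1ccc(C(F)(F)F)cc1NCC1=NCCN1`, has not yet been measured. It differs from compound 2 in one place: trifluoromethyl in place of chloro on an aromatic carbon.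

Among the measured compounds shown here, no measured pair exchanges chloro for trifluoromethyl, so the single recorded step bears on this change only loosely: it exchanges a different pair of groups at the same place. For the measured compounds named here, both measured compounds reach maxima close to the reference, and the one recorded step was small. Compound 3 is therefore expected to show a step of a number 3 percentage points lower from compound 2 to compound 3 (within the scatter) in this assay, a change not beyond the scatter. For compound 3 the expected value in this assay is 100%, with a range from 85% to 115%.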

Compound 3, largest response reached (reported as maximum), in percent of the reference or control that the assay uses: 114%
Estimate against measurement, compound 3: 14 percentage points below; measured number inside the range.
By their numbers in this assay, from the lowest: compound 1; then compound 2; then compound 3.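

At the aromatic carbon para to a methylsulfanyl group, trifluoromethyl in place of chloro gives in this assay a number 11 percentage points higher from compound 2 to compound 3 (beyond the scatter) and so shows that the maximal response still moves beyond the scatter when the group at this place changes a second time, here starting from chloro rather than methoxy. Over the three groups at this place, the numbers rise from methoxy through chloro to trifluoromethyl, with a number 22 percentage points higher from compound 1 to compound 3 (beyond the scatter) as the widest step in the set, and compound 3 at 114% as the highest number in the series so far. No measured property of these groups accompanies the numbers, so this order stands without any explanation.

As far as these compounds go, whether the rise continues or reverses with other groups at this place, such as a nitrile, a methyl group, an amine or a carboxylic acid, remains open, since three groups give an order but no rule. Also open, from the compounds shown here alone, is whether the exchange of chloro for trifluoromethyl gives a similar step when the methylsulfanyl group is replaced by a methoxy group or a longer chain.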